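From a bromo to a 3-chlorophenyl on an amide

The compounds below may be only part of what the source reports. "The series", "measured", "known", "first", "only" and "open" are said of these compounds alone.

The study measures, in an in vitro assay on HEK-293T cells for displacement of a labelled ligand from metabotropic glutamate receptor 5 (Homo sapiens), read by scintillation counting (a lower number here means a stronger inhibitor, a higher number a weaker inhibitor), a small group of compounds. Compound 1, `Cc1nc(C#Cc2cc(F)cc(-c3cccnc3)c2)cs1`, gives 2.7 nM in this assay. Compound 2, `Cc1cccc(NC(=O)c2ccc(Br)cc2)n1`, belongs to a different series, built on a shared core with an amide and a bromo substituent. In this assay compound 2 reaches only a limit, > 10000 nM, so no number is known for it. Its position is given by the limit of > 10000 nM in this assay, at which 1 of the 2 values shown sits, which marks where the weaker of the two measured values sits.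

Compound 3, `Cc1cccc(NC(=O)c2ccc(-c3cccc(Cl)c3)cc2)n1`, is obtained from compound 2 by the change (3-chlorophenyl in place of bromo on an aromatic carbon). Among the compounds with values here, no step between two measured compounds is available to gauge a change of this kind, and the limit for compound 2 leaves the size of any step open. Since compound 2 sits at a limit, the expected step of an at least 3.3-fold lower number from compound 2 to compound 3 (0.52 log units; beyond the scatter) can be read only from the estimate itself. Compound 3 is estimated to give 3000 nM in this assay, with a likely range from 300 nM to 30000 nM.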

Compound 3, inhibition constant: 3330 nM
The estimate for compound 3 lay 1.1-fold (0.05 log units) below the measured number, and the stated range covers the measured number.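

Placing a 3-chlorophenyl instead of bromo on this aromatic carbon, para to a large group, turns a compound without a number into one with a measurable value: in this assay compound 3 gives 3330 nM. The change amounts to an at least 3.0-fold lower number from compound 2 to compound 3 (0.47 log units; beyond the scatter), so this position accepts a six-membered aromatic ring of carbon only, and the affinity is at least kept, with a clear gain over the bromo. The full size of the step stays unknown, since compound 2 has only a limit and no number: the limit of > 10000 nM in this assay, at which 1 of the 3 values shown sits.

The compounds shown leave open whether the chlorine on the new ring contributes to the gain at all, or whether the ring alone accounts for it, and whether the chlorine's place on that ring matters. They also leave open how other groups at this carbon would fare, such as an amine, a carboxylic acid or a longer chain, and whether any of them could bring this amide series closer to the value of 2.7 nM that compound 1 gives.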